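Lactam to benzamide swap on the shared core: clearance notes

This account rests on a few compounds, and the source may have more. Where it says the series, first, only, none or still open, it means among the compounds named here.

Measured so far:
Compound 1 `Cn1cc(-c2cnc(NCc3c(F)ccc4c3CCO4)c3cn[nH]c(=O)c23)cn1` gives 21 mL.min-1.g-1 in an ADME assay on microsomes from liver (Homo sapiens) for metabolic stability, read by LC-MS, using NADPH, with stated times of 5 min and 30 min, tested at 1 uM; on this read-out lower numbers stand for slow clearance and higher numbers for fast clearance.
Compound 2 `C[C@@H]1CC(=O)N(c2cnc(NCc3c(F)ccc4c3CCO4)n3cnnc23)C1` returns a limit in this assay rather than a number, < 3 mL.min-1.g-1.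

Compound 2 thus sits at the floor of what this assay can report: the limit of < 3 mL.min-1.g-1 in this assay, at which 1 of the 2 values shown sits. Compound 3 `CN(C(=O)c1ccccc1)c1cnc(NCc2c(F)ccc3c2CCO3)n2cnnc12` differs from compound 2 in one place: benzoyl(methyl)amino in place of 4-methyl-2-oxopyrrolidin-1-yl on an aromatic carbon. Going by the values given here, no measured pair sets a scale for such a change. The expectation is an upward step an at least 3.3-fold higher number from compound 2 to compound 3 (0.52 log units; beyond the scatter), beyond the usual scatter. Compound 3 is estimated at 10 mL.min-1.g-1, within 3 mL.min-1.g-1 to 35 mL.min-1.g-1.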

Compound 3, intrinsic clearance in microsomes: > 300 mL.min-1.g-1
Compound 3 ended at the assay's limit (the forecaster's own chance of this, stated with the estimate: 20%); at least 30-fold (1.47 log units) between middle value and limit.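

On the shared core, benzoyl(methyl)amino in place of 4-methyl-2-oxopyrrolidin-1-yl on an aromatic carbon gives an at least 100-fold higher number from compound 2 to compound 3 (2.00 log units; beyond the scatter) in this assay, so a change at this one position spans the assay's reportable range. Compound 3 returns a limit, not a number: the limit of > 300 mL.min-1.g-1 in this assay, at which 1 of the 3 values shown sits. Both ends of the step are limits, so its printed size is a minimum.

Which part of the entering group drives the rise stays open. Equally open, going by these compounds, is whether acetyl(methyl)amino, or a pyridine ring in place of the benzene ring, would bring the read-out back towards compound 2.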